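Methoxy in Place of Bromo in Two Different Settings

The compounds below may be only part of what the source reports. "The series", "measured", "known", "first", "only" and "open" are said of these compounds alone.

Three compounds have been measured in an assay on HEK293 cells for displacement of a labelled ligand from Neuronal acetylcholine receptor; alpha4/beta2 (Homo sapiens); a lower number here means a stronger inhibitor, a higher number a weaker inhibitor:

compound 1 `COc1cc(N2CCCNCC2)cnc1Cl` gives 0.676 nM
compound 2 `Clc1ncc(N2CCCNCC2)cc1Br` gives 1.41 nM
compound 3 `Brc1cncc(N2CCCNCCC2)c1` gives 2.82 nM

Compound 2 and compound 1 differ in one place, (methoxy in place of bromo on an aromatic carbon). That step was a 2.1-fold lower number from compound 2 to compound 1 (0.32 log units; beyond the scatter). The same kind of change leads from compound 3 to compound 4 `COc1cncc(N2CCCNCCC2)c1`, namely (methoxy in place of bromo on an aromatic carbon). The surroundings of the place are not identical: in compound 2 the site is ortho to a chloro group (1 heavy atom) and meta to a group of 7 heavy atoms, in compound 3 it is meta to a group of 8 heavy atoms. How the core of compound 3 differs from that of compound 2 is not broken down here; compound 2 and compound 3 give numbers within the scatter of each other.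

Resting on the earlier step of a 2.1-fold lower number from compound 2 to compound 1 (0.32 log units; beyond the scatter), a step of similar size is expected, a 2.0-fold lower number from compound 3 to compound 4 (0.30 log units; within the scatter). Compound 4 is therefore estimated at 1.4 nM in this assay, with a range from 0.6 nM to 3.5 nM.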

Compound 4, half-maximal inhibitory concentration: 1 nM
Estimate against measurement, compound 4: 1.4-fold (0.15 log units) above; low and high end bracket the measured number.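

In this assay, methoxy in place of bromo on an aromatic carbon gave a 2.8-fold lower number from compound 3 to compound 4 (0.45 log units; beyond the scatter), so the direction of the earlier step recurred on a second core. The two steps agree in size: the same change on two cores in this assay, a 2.1-fold lower number (0.32 log units; beyond the scatter) from compound 2 to compound 1 and a 2.8-fold lower number (0.45 log units; beyond the scatter) from compound 3 to compound 4, 1.4-fold (0.13 log units) apart, within the scatter of two such steps. Among these compounds, this rests on only two pairs, with the site in different surroundings in each, so it shows that the change carried over between these two cores but not that it would carry over to other cores, nor why it lowers the number.

The compounds shown hold only bromo and methoxy at this place, so it remains open how an amine, a nitrile or a longer ether chain would compare there. They also leave open how the change would read in any other assay.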